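Compound 3 to compound 4: a new amide-nitrogen group

A few compounds are considered here, and "the series" means these few. Any claim that something is new, unique, unknown or untested is made for them only; others in the source may bear on it.

Compound 3, `Cc1cc(C)cc(S(=O)(=O)c2c(C(=O)NC(C)c3cc(F)cc(F)c3)[nH]c3ccc(Cl)cc23)c1`, stands at a limit in an ADME assay on MT4 cells (Homo sapiens) for cytotoxicity, read by MTT assay (on this read-out higher numbers stand for lower toxicity in this test and lower numbers for higher toxicity in this test), with > 49700 nM and no number. Compound 1, `Cc1cc(C)cc(S(=O)(=O)c2c(C(=O)NCc3cccc(N)c3)[nH]c3ccc(Cl)cc23)c1`, also stands at a limit, with > 53400 nM. Compound 2, `Cc1cc(C)cc(S(=O)(=O)c2c(C(=O)Nc3ccnc(C#N)c3)[nH]c3ccc(Cl)cc23)c1`, is the only one of the three with a number, at 6840 nM.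

The next structure is compound 4, `Cc1cc(C)cc(S(=O)(=O)c2c(C(=O)NCc3ccc4nc(N)[nH]c4c3)[nH]c3ccc(Cl)cc23)c1`, and the change is a group of 11 heavy atoms (8 carbon, 3 nitrogen; one five-membered aromatic ring with 2 hetero atoms, one six-membered aromatic ring of carbon only) in place of a group of 10 heavy atoms (8 carbon, 2 fluorine; one six-membered aromatic ring of carbon only), on an amide-type nitrogen. Two measured steps at the same amide-type nitrogen bear on it: an at least 7.8-fold lower number from compound 1 to compound 2 (0.89 log units; beyond the scatter) and an at least 7.2-fold higher number from compound 2 to compound 3 (0.86 log units; beyond the scatter). The third, a step that the two limits leave unreadable from compound 1 to compound 3, gives no size to work with.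

Changes at this nitrogen have therefore moved this assay beyond the scatter, but only compound 2 lies on the lower side. With two of the three compounds at limits, a small move toward a lower number is expected, and a further limit remains quite possible. The expected size is an at least 1.9-fold lower number from compound 3 to compound 4 (0.29 log units; that floor lies within the scatter). For compound 4 the estimated value is 25000 nM, with an expected range from 6000 nM to 80000 nM.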

Compound 4, half-maximal cytotoxic concentration: 5890 nM
Compound 4: the middle estimate sits 4.2-fold (0.63 log units) above what was measured; the whole stated range lies above it.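

Notes on the amide-type nitrogen in this assay: compound 2 no longer stands alone on the lower side, since a second and very different group gives a 1.2-fold lower number from compound 2 to compound 4 (0.06 log units; within the scatter). The cleanest comparison is an at least 9.0-fold lower number from compound 1 to compound 4 (0.95 log units; beyond the scatter), where the saturated chain carbon on the amide-type nitrogen stays and 2-amino-1H-benzimidazol-6-yl replaces 3-aminophenyl, so an amino-bearing aromatic group on that chain does not by itself keep a compound at a limit; the other group swap gives an at least 8.4-fold lower number from compound 3 to compound 4 (0.92 log units; beyond the scatter). Compound 3 is a limit and not a number, so that step gives only a floor: the limit of > 49700 nM in this assay, at which 1 of the 4 values shown sits.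

The step between compound 1 and compound 3 cannot be read, which leaves their order open. As far as these compounds go, it also remains open whether 1H-benzimidazol-6-yl without its amino group, on the same chain carbon, would stay with compound 4 or move toward the limits.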